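The source may report more compounds than this note shows. Statements on the series, on what has been measured and on what is new or still open speak of the compounds shown alone.

Among the measured compounds shown here, in an ADME assay on PC-12 cells (Rattus norvegicus) for cytotoxicity, read by MTT assay, with a stated time of 24 h (a lower number here means that less compound is tolerated, a higher number that more compound is tolerated), three compounds built on a shared core have numbers so far. Compound 1 `COc1ccc(N2CCN(CC#CCOC(=O)c3sc4ncnc(N5CCCCC5)c4c3C)CC2)cc1` gives 140 ug/mL, compound 2 `Cc1ccc(C#N)c(N2CCN(CC#CCOC(=O)c3sc4ncnc(N5CCCCC5)c4c3C)CC2)c1` gives 114 ug/mL, and compound 3 `Cc1c(-c2nnc(-c3ccccc3)o2)sc2ncnc(N3CCCCC3)c12` gives 146 ug/mL. The value of compound 3 lies within the usual scatter of both other values, so no order can be read among the three.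

Compound 4 `Cc1c(-c2nnc(-c3ccc(Cl)cc3)o2)sc2ncnc(N3CCCCC3)c12` departs from compound 3 by a single change, (chloro in place of hydrogen on an aromatic carbon). Its phenyl becomes 4-chlorophenyl, with chloro in place of hydrogen on an aromatic carbon, para to a large group.

For the measured compounds named here, no measured step shows this exchange, so the evidence is indirect. Going by the values given here, the only measured step, a 1.2-fold lower number from compound 1 to compound 2 (0.09 log units; within the scatter), puts 2-cyano-5-methylphenyl in place of 4-methoxyphenyl on an amine nitrogen in a ring, elsewhere in a different series of the core's substituents. Even that exchange of a whole aryl group stays within the scatter, and compound 3 itself sits level with both of those compounds. No step beyond the scatter is therefore expected here, and the estimate is a 1.2-fold lower number from compound 3 to compound 4 (0.07 log units; within the scatter). In this assay, compound 4 is expected at 125 ug/mL, with an estimated range of 65 ug/mL to 210 ug/mL.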

Compound 4, half-maximal cytotoxic concentration: 151 ug/mL
Estimate against measurement, compound 4: 1.2-fold (0.08 log units) below; the range from low to high includes it.
By their numbers in this assay, from the lowest: compounds 2, 1, 3 and 4 (each within the scatter of the next).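

The phenyl of compound 3 now has its first measured exchange: in this assay, chloro in place of hydrogen on an aromatic carbon, para to a large group, gives a 1.0-fold higher number from compound 3 to compound 4 (0.01 log units; within the scatter). Among the compounds shown here, until now, the only measured step had exchanged one whole aryl group for another carrying the longer chain, so it said nothing about this place; here a single added chlorine on the six-membered aromatic ring of compound 3 leaves the number within the scatter, and no order can be read between the two compounds. Nothing available explains why this exchange leaves the number level, and no supporting measurement bears on it.

One chloro group at one place cannot show whether this position tolerates every substituent in this assay, so a primary amine, a carboxylic acid or a longer alkyl chain at the same place remains an open case. On these data alone, it also remains open whether chloro would behave in the same way elsewhere on this phenyl, or on the aryl groups of the compounds carrying the longer chain.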